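Adding a methoxy group to compound 1: an expectation

A few compounds are considered here, and "the series" means these few. Any claim that something is new, unique, unknown or untested is made for them only; others in the source may bear on it.

Compound 1 `Clc1cccc(-n2ncnc2NCc2ccccc2)c1Cl`: in a functional assay for antagonist activity at P2X purinoceptor 7 (Rattus norvegicus), read by FLIPR and calcium flux (a lower number here means a stronger inhibitor, a higher number a weaker inhibitor), compound 1 gives 209 nM.
Compound 2 `COc1cccc(CNc2ncnn2-c2cccc(Cl)c2Cl)c1`: in this assay compound 2 gives 1380 nM.

For the measured compounds named here, compound 1 has the lowest number of the two measured compounds; its only neighbour is compound 2, reached by the step of a 6.6-fold higher number from compound 1 to compound 2 (0.82 log units; beyond the scatter). Compound 3 `COc1ccc(CNc2ncnn2-c2cccc(Cl)c2Cl)cc1` differs from compound 1 by methoxy in place of hydrogen on an aromatic carbon. Going by the values given here, the one measured step that bears on this change is the methoxy addition that gives compound 2, which was modest and went to a higher number. A methoxy group at another position on the same ring is therefore expected to move the number upward as well, though a single precedent leaves the size uncertain. Compound 3 is expected to give about 900 nM in this assay, between 300 nM and 3000 nM, an expected step of a 4.3-fold higher number from compound 1 to compound 3 (0.63 log units; beyond the scatter).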

Compound 3, half-maximal inhibitory concentration: 10500 nM
Compound 3: the middle estimate sits 12-fold (1.07 log units) below what was measured; measured number outside the range, above it.
By their numbers in this assay, from the lowest: compound 1; then compound 2; then compound 3.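

Placed para to a large group, the methoxy group costs far more than the one earlier step suggested: a 50-fold higher number from compound 1 to compound 3 (1.70 log units; beyond the scatter) is the largest step shown. The same exchange of hydrogen for methoxy on the same ring therefore has no single size, and its effect depends on where the group sits: in this assay compound 2 gives 1380 nM while compound 3 gives 10500 nM for a group differing only in its place. Nothing available accounts for this difference between the two positions.

The compounds shown leave open whether the large rise belongs to methoxy itself or to any substituent at this place. A fluorine, a methyl or a hydroxyl there could separate these readings, and an ethoxy would show how a longer chain fares.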